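From an open-chain amide to a pyrrolidine amide

The source may report more compounds than this note shows. Statements on the series, on what has been measured and on what is new or still open speak of the compounds shown alone.

Going by the values given here, compound 1 `CCCNC(=O)Cn1nc(N)c2c(C(F)(F)F)cc(-c3ccccc3)nc21` gives 14900 nM in a functional assay on MCF7 cells (Homo sapiens) for cytotoxicity, read by MTT assay, with a stated time of 24 h (on this read-out lower numbers stand for stronger inhibition and higher numbers for weaker inhibition), the highest number among the three compounds measured so far. Compound 2 `Nc1nn(CC(=O)NCc2ccco2)c2nc(-c3ccccc3)cc(C(F)(F)F)c12` gives 5000 nM in this assay, and compound 3 `Nc1nn(CC(=O)N2CCCCC2)c2nc(-c3ccccc3)cc(C(F)(F)F)c12` gives 4100 nM. Compound 4 `Nc1nn(CC(=O)N2CCCC2)c2nc(-c3ccccc3)cc(C(F)(F)F)c12` differs from compound 1 by pyrrolidin-1-yl in place of propylamino on a carbonyl carbon. Among the compounds with values here, the closest precedent is the change from compound 1 to compound 3, which brought a 3.6-fold lower number from compound 1 to compound 3 (0.56 log units; beyond the scatter); the change to compound 2 brought a 3.0-fold lower number from compound 1 to compound 2 (0.47 log units; beyond the scatter), while a 1.2-fold lower number from compound 2 to compound 3 (0.09 log units; within the scatter) lies within the scatter. A modest downward step is therefore expected for compound 4, estimated as a 3.0-fold lower number from compound 1 to compound 4 (0.47 log units; beyond the scatter). The expected value for compound 4 is 5000 nM, with a range from 2500 nM to 10000 nM.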

Compound 4, half-maximal inhibitory concentration: 15900 nM
Compound 4: middle estimate off by 3.2-fold (0.50 log units), on the low side, outside the stated range (above it).
By their numbers in this assay, from the lowest: compounds 3 and 2 (each within the scatter of the next); then compounds 1 and 4 (each within the scatter of the next).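

Pyrrolidin-1-yl in place of propylamino on the carbonyl carbon left compound 4 level with compound 1 in this assay (a 1.1-fold higher number from compound 1 to compound 4 (0.03 log units; within the scatter)), so a ring at this place does not by itself go with a lower number. The identity of the ring counts here: piperidin-1-yl and pyrrolidin-1-yl do not read alike (a 3.9-fold higher number from compound 3 to compound 4 (0.59 log units; beyond the scatter)), and the open-chain ((furan-2-yl)methyl)amino amide also stands lower than the pyrrolidine amide (a 3.2-fold higher number from compound 2 to compound 4 (0.50 log units; beyond the scatter)). No measurement given here accounts for these differences.

Going by these compounds, whether a morpholine ring on the same carbonyl carbon reads like compound 3 or like compound 4 stays open.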